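A few compounds are considered here, and "the series" means these few. Any claim that something is new, unique, unknown or untested is made for them only; others in the source may bear on it.

Measured so far in a physicochemical assay for solubility, with a stated time of 18 h, at pH 7.4; a lower number here means a less soluble compound, a higher number a more soluble compound:
compound 1 `c1ccc(-c2ccc3c(NCCCNCc4ccco4)ccnc3c2)cc1` gives 32000 nM;
compound 2 `CCC(CC)c1ccc2c(NCCCNCc3cccc(OC)c3O)ccnc2c1` gives 4200 nM;
compound 3 `CCC(CC)c1ccc2c(NCCCNCc3cc(F)ccc3OC)ccnc2c1` gives 4200 nM.

Going by the values given here, compound 2 stands level with compound 3 and together with it at the lowest of the three numbers; compound 1 carries a phenyl where compound 2 carries pentan-3-yl, and its value is markedly higher, but the two also differ in the aryl group on the chain, so no single-place step is available between them.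

Compound 4 `COc1cccc(CNCCCNc2ccnc3cc(CC(C)C)ccc23)c1O` differs from compound 2 by isobutyl in place of pentan-3-yl on an aromatic carbon. Among the compounds with values here, the only measured step, no change at the digits printed from compound 2 to compound 3 (within the scatter), concerns the aryl group on the chain, not the alkyl on the core, so it does not bear directly on this change. With one carbon fewer and a branched chain in both cases, a small rise at most, within the scatter, is expected: a 1.3-fold higher number from compound 2 to compound 4 (0.12 log units; within the scatter). Compound 4 is therefore estimated at 5500 nM, with a range of 2500 nM to 12000 nM.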

Compound 4, solubility: 4200 nM
Beside the measured number, compound 4's estimate is 1.3-fold (0.12 log units) above it; the measured number falls inside the stated range.
By their numbers in this assay, from the lowest: compounds 2, 3 and 4 (each within the scatter of the next); then compound 1.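

In this assay, going by these compounds alone, the first step at this aromatic carbon of the core reads no change at the digits printed from compound 2 to compound 4 (within the scatter) with the 2-hydroxy-3-methoxyphenyl group held constant on the chain. Isobutyl and pentan-3-yl are thus not separated in this read-out, whereas the earlier step concerned only the aryl group on the chain. No evidence on the reason for this result is available here.

Open, as far as these compounds go, is whether a carboxylic acid, an amine or a longer chain at this position would stay level with compound 2. The phenyl of compound 1 cannot be read as a single step.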